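The compounds below may be only part of what the source reports. "The series", "measured", "known", "first", "only" and "open" are said of these compounds alone.

Measured in an assay for inhibition of Nitric oxide synthase, inducible (Homo sapiens), read by scintillation counting, with a stated time of 30 min, tested at 1 mM; on this read-out lower numbers stand for less inhibition and higher numbers for more inhibition at the one concentration tested (going by the name of the read-out):
compound 1 `CC(=O)NCCC(=O)c1cc(Cl)ccc1N`: 19.7%
compound 2 `Nc1ccc(Cl)cc1C(=O)CCNC(=O)C1CC1`: 5.37%
compound 3 `Nc1ccc(Cl)cc1C(=O)CCNC(=O)c1ccccc1`: 26.6%

Compound 3 stands highest of the three numbers in this assay; its gap to compound 1 is within the scatter, a number 6.9 percentage points higher from compound 1 to compound 3 (within the scatter), while its gap to compound 2 is beyond it, a number 21.2 percentage points higher from compound 2 to compound 3 (beyond the scatter). Compound 4 `CCNC(=O)NCCC(=O)c1cc(Cl)ccc1N` differs from compound 3 at the carbonyl carbon: ethylamino in place of phenyl on a carbonyl carbon. Among the measured compounds shown here, the steps that bear on this are the two earlier exchanges at the same carbonyl carbon, a number 14.3 percentage points lower from compound 1 to compound 2 (beyond the scatter) and a number 21.2 percentage points higher from compound 2 to compound 3 (beyond the scatter): the groups without a six-membered aromatic ring gave the lower numbers, and ethylamino has no ring. A modest fall beyond the scatter is therefore expected for compound 4, a number 14.6 percentage points lower from compound 3 to compound 4 (beyond the scatter). Compound 4 is estimated at 12%, with a range from 0% to 28%.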

Compound 4, a percentage reported as inhibition, at one concentration (the size of the read-out at that concentration, not a potency): 78.6%
The estimate for compound 4 lay 66.6 percentage points below the measured number, outside the stated range (above it).
By their numbers in this assay, from the lowest: compound 2; then compounds 1 and 3 (each within the scatter of the next); then compound 4.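

In this assay, the group on this carbonyl carbon can move the number far more than the earlier exchanges showed: ethylamino gives a number 52 percentage points higher from compound 3 to compound 4 (beyond the scatter), a number 73.2 percentage points higher from compound 2 to compound 4 (beyond the scatter) and a number 58.9 percentage points higher from compound 1 to compound 4 (beyond the scatter). A six-membered aromatic ring is therefore not needed for the highest number in this set, and among these groups only ethylamino brings a nitrogen and a hydrogen-bond donor to this place. No measurement shown here accounts for the rise.

From the compounds shown here alone, whether it follows the nitrogen or the ethyl chain remains open; methylamino, propylamino and dimethylamino at this carbonyl carbon would address that. Readings at one concentration also leave potency undefined.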